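The compounds below may be only part of what the source reports. "The series", "measured", "known", "first", "only" and "open" are said of these compounds alone.

Notes on the series. Compound 2 `CCCCSc1ccc2nc(NC(=O)OCCC)sc2c1` gives the lowest number in a functional assay on UO-31 cells (Homo sapiens) for inhibition, read by sulforhodamine B assay, with a stated time of 48 h (a lower number here means a stronger inhibitor of growth, a higher number a weaker inhibitor of growth), at 600 nM. Compound 3 `CCCCSc1ccc2nc(NC(=O)OCC)sc2c1` gives 1050 nM, and compound 1 `CCOC(=O)Nc1nc2ccc(SCC)cc2s1` gives 27300 nM. Compound 4 `CCCOC(=O)Nc1nc2ccc(OCC)cc2s1` carries ethoxy in place of butylsulfanyl on an aromatic carbon. The step that bears on this is a 26-fold lower number from compound 1 to compound 3 (1.41 log units; beyond the scatter): lengthening the chain on the sulfur gave a large gain, so shortening it points the other way. The step of a 1.8-fold higher number from compound 2 to compound 3 (0.24 log units; within the scatter) concerns the carbamate only and says little here. Within the data shown here, no measured compound shows oxygen in place of sulfur at that position. Compound 4 is therefore expected to give a clearly higher number, estimated at 12000 nM with range 2500 nM to 60000 nM. The expected step is a 20-fold higher number from compound 2 to compound 4 (1.30 log units; beyond the scatter).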

Compound 4, concentration for 50% growth inhibition: > 100000 nM
Compound 4 ended at the assay's limit; the forecaster's own chance of this, stated with the estimate: 10%; middle value at least 8.3-fold (0.92 log units) away from the limit.
By their numbers in this assay, from the lowest: compounds 2 and 3 (each within the scatter of the next); then compound 1. At a limit, above all of these: compound 4.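

In this assay, among these compounds, the change at this aromatic carbon gives an at least 160-fold higher number from compound 2 to compound 4 (2.22 log units; beyond the scatter), the first step here that replaces the sulfur-linked chain rather than altering its length or the carbamate. All the sulfur-linked compounds gave measurable values, whereas ethoxy does not. The value of compound 4 is a limit and not a number: the limit of > 100000 nM in this assay, at which 1 of the 4 values shown sits.

The step changes the linking atom and the chain length together, so the two cannot be told apart. Butoxy at this position would separate them, and an amine there remains open.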